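Sulfonyl substituent changes and liver clearance in one series

The compounds below may be only part of what the source reports. "The series", "measured", "known", "first", "only" and "open" are said of these compounds alone.

Measured compounds:
compound 1 `CC(C)COc1ncc(-c2cc(F)c(-c3nnc(S(=O)(=O)CC4CC4)[nH]3)cc2F)cc1Cl` — 58 uL/min
compound 2 `CC(C)COc1ncc(-c2cc(F)c(-c3nnc(S(=O)(=O)NC4CC4)[nH]3)cc2F)cc1Cl` — 54 uL/min

In an ADME assay on microsomes from liver (Rattus norvegicus) for metabolic stability (a higher number here means faster removal of the compound, a lower number slower removal), compound 1 gives 58 uL/min and compound 2 gives 54 uL/min. The two numbers sit together: a 1.1-fold lower number from compound 1 to compound 2 (0.03 log units; within the scatter). Going by the values given here, compound 2 therefore stands with compound 1 on the numbers so far, and nothing separates the pair beyond the scatter.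

Compound 3 `CC(C)COc1ncc(-c2cc(F)c(-c3nnc(S(=O)(=O)C4CCC4)[nH]3)cc2F)cc1Cl` is the next member. It differs from compound 2 in one place: cyclobutyl in place of cyclopropylamino on a sulfonyl sulfur. The change once again replaces the group on the sulfonyl sulfur, this time with a carbon-only ring and no hydrogen-bond donor.

Among the compounds with values here, the only measured step that bears on this is a 1.1-fold lower number from compound 1 to compound 2 (0.03 log units; within the scatter), which also exchanged the group on the sulfonyl sulfur and moved the number by less than the scatter. Within the data shown here, with a single step of that size as the sole guide, no step beyond the scatter is expected here either, in this assay, and the direction is not called.

For compound 3 a value near 58 uL/min is expected, within the range 30 uL/min to 115 uL/min. The step of a 1.1-fold higher number from compound 2 to compound 3 (0.03 log units; within the scatter) is accordingly estimated to stay within the scatter.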

Compound 3, intrinsic clearance in a liver preparation (reported as CLH), per the amount of preparation that the assay uses: 62 uL/min
Compound 3: the middle estimate sits 1.1-fold (0.03 log units) below what was measured, within the range that was stated.
By their numbers in this assay, from the lowest: compounds 2, 1 and 3 (each within the scatter of the next).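

Replacing cyclopropylamino with cyclobutyl on a sulfonyl sulfur removes the only hydrogen-bond donor in that substituent, and the number in this assay stays within the scatter (a 1.1-fold higher number from compound 2 to compound 3 (0.06 log units; within the scatter)), so among the compounds shown the presence of that donor goes with no readable difference in this read-out. Going by these compounds alone, the second comparison stays entirely among carbon-only substituents, and replacing cyclopropylmethyl with cyclobutyl also stays within the scatter (a 1.1-fold higher number from compound 1 to compound 3 (0.03 log units; within the scatter)), which means that compound 1, compound 2 and compound 3 now form a flat set of three, with no compound going against that description and no substituent separated from the others at this place. No supporting measurement is available to explain why these substituents give such similar numbers.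

As far as these compounds go, what remains open is whether this flatness extends to substituents of a different kind on the sulfonyl sulfur, such as a morpholine, a dimethylamino group, a carboxylic acid or a longer straight alkyl chain. From the compounds shown here alone, it is also open whether any change away from the sulfonyl sulfur, elsewhere on the shared core, would move the number in this assay beyond the scatter.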